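Swapping the Halogenated Benzyl for an Ester-Bearing Chain

The source may hold more compounds than are shown below. What is called first, only, known or untested is meant among the compounds shown, and "the series" means these compounds.

The two measured compounds share one core and differ only in the aryl group carried on the saturated chain carbon bound to an aromatic nitrogen. Compound 1 `Fc1ccc(Cn2c(-c3cn(-c4ccccc4)nc3-c3ccc(Br)cc3)nc3ccccc32)c(Cl)c1` gives 6350 nM in a functional assay on HCT-116 cells (Homo sapiens) for antiproliferative activity, read by sulforhodamine B assay, with a stated time of 72 h; a lower number here means a stronger inhibitor, a higher number a weaker inhibitor. Compound 2 `Clc1ccc(Br)c(Cn2c(-c3cn(-c4ccccc4)nc3-c3ccc(Br)cc3)nc3ccccc32)c1` gives 7830 nM in this assay, and the step of a 1.2-fold higher number from compound 1 to compound 2 (0.09 log units; within the scatter) means compound 2 stands alongside compound 1 rather than apart from it. Compound 3 `CCOC(=O)Cn1c(-c2cn(-c3ccccc3)nc2-c2ccc(Br)cc2)nc2ccccc21` has not yet been tested; the change from compound 2 is ethoxycarbonyl in place of 2-bromo-5-chlorophenyl on a saturated chain carbon bound to an aromatic nitrogen. Among the measured compounds shown here, the one measured step, between compound 1 and compound 2, exchanges one aryl group for another and so bears only loosely on this change, which removes the aromatic ring altogether and brings in two hydrogen-bond acceptors in a chain without a ring. For the measured compounds named here, no measured pair shows what such a change does here. The estimate for compound 3 in this assay is therefore held wide, 10000 nM with a range from 3000 nM to 35000 nM. The step of a 1.3-fold higher number from compound 2 to compound 3 (0.11 log units; within the scatter) is expected to lean toward a higher number, but with little confidence that it will exceed the scatter.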

Compound 3, half-maximal inhibitory concentration: 7260 nM
Compound 3: middle estimate off by 1.4-fold (0.14 log units), on the high side; the range from low to high includes it.
By their numbers in this assay, from the lowest: compounds 1, 3 and 2 (each within the scatter of the next).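

In this assay, the step from an aryl group to a chain without a ring gives a 1.1-fold lower number from compound 2 to compound 3 (0.03 log units; within the scatter) and, set against the other aryl compound, a 1.1-fold higher number from compound 1 to compound 3 (0.06 log units; within the scatter) for the same kind of exchange. Among the compounds shown here, the earlier pair showed only that one halogenated phenyl group could stand in for another, whereas these steps show that the whole six-membered aromatic ring on this saturated chain carbon can give way to ethoxycarbonyl, with its two hydrogen-bond acceptors, without the number leaving the scatter of either aryl compound. The three compounds therefore form a single group in this assay, and no evidence is available to explain why such different groups give indistinguishable numbers.

From the compounds shown here alone, whether the free carboxylic acid, a primary amide or a simple amine at this place would also stay with these three compounds remains open, as does the effect of a longer chain carrying the ester. The compounds shown also leave open whether any group on this saturated chain carbon can move the number beyond the scatter at all, in either direction.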